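The source may report more compounds than this note shows. Statements on the series, on what has been measured and on what is new or still open speak of the compounds shown alone.

Of the compounds shown here, three built on one shared core have been tested in a functional assay on UACC-62 cells (Homo sapiens) for inhibition, read by sulforhodamine B assay, with a stated time of 48 h; on this read-out lower numbers stand for stronger inhibition of growth and higher numbers for weaker inhibition of growth. Compound 1, `Nc1cc(N)c2nc(-c3ccccc3)c(Oc3ccc(Cl)c(Cl)c3)nc2c1`, gives 47900 nM. Compound 2, `CCOC(=O)[C@H](CCC(=O)O)NC(=O)c1ccc(Sc2nc3cc(N)cc(N)c3nc2-c2ccccc2)cc1`, gives 38900 nM, a number that lies within the scatter of compound 1, so the two cannot be told apart. Compound 3, `COc1cc(CNc2nc3cc(N)cc(N)c3nc2-c2ccccc2)cc(OC)c1OC`, gives 15500 nM, which sits beyond the scatter below compound 1; compound 1 therefore stands highest of the three numbers. Compound 4, `Nc1cc(N)c2nc(-c3ccccc3)c(Sc3ccc(Cl)c(Cl)c3)nc2c1`, has not yet been measured. It differs from compound 1 in one place: (3,4-dichlorophenyl)sulfanyl in place of 3,4-dichlorophenoxy on an aromatic carbon. Going by the values given here, no measured pair shows this exchange on its own, so the step is expected to be small, a 1.4-fold lower number from compound 1 to compound 4 (0.14 log units; within the scatter), not beyond the scatter. Compound 4 is expected to give 35000 nM, between 12000 nM and 100000 nM.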

Compound 4, concentration for total growth inhibition: 42700 nM
For compound 4 the middle estimate is 1.2-fold (0.09 log units) below the measured one; the measured number falls inside the stated range.
By their numbers in this assay, from the lowest: compound 3; then compounds 2, 4 and 1 (each within the scatter of the next).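

In this assay the exchange of 3,4-dichlorophenoxy for (3,4-dichlorophenyl)sulfanyl on this aromatic carbon gives a 1.1-fold lower number from compound 1 to compound 4 (0.05 log units; within the scatter) and so the two compounds cannot be told apart. At this position, then, an oxygen link and a sulfur link to the same dichlorophenyl ring give the same result within the scatter. Nothing measured here explains this match. Still open, as far as these compounds go, is whether an amine link to the same dichlorophenyl ring would keep the number in this range, and whether a carboxylic acid on that ring would shift it.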